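A few compounds are considered here, and "the series" means these few. Any claim that something is new, unique, unknown or untested is made for them only; others in the source may bear on it.

Measured so far in a functional assay on MCF7 cells (Homo sapiens) for antiproliferative activity, read by CCK-8 assay, with a stated time of 72 h; a lower number here means a stronger inhibitor, a higher number a weaker inhibitor:

Compound 1, `Cc1nc(C)c(/C=C/C(=O)c2ccc(NC(=O)c3ccc(F)cc3F)cc2)nc1C`: 1610 nM
Compound 2, `Cc1nc(C)c(/C=C/C(=O)c2ccc(NC(=O)c3ccccc3F)cc2)nc1C`: 1270 nM
Compound 3, `COc1cccc(OC)c1C(=O)Nc1ccc(C(=O)/C=C/c2nc(C)c(C)nc2C)cc1`: 2470 nM

All three share one core, a chalcone-like chain linking an amide-bearing ring to a trimethylated heteroaromatic ring, and differ only in the aryl group attached to the amide carbonyl carbon. Compound 3 carries the highest number of the three, yet its two measured steps, a 1.5-fold higher number from compound 1 to compound 3 (0.19 log units; within the scatter) and a 1.9-fold higher number from compound 2 to compound 3 (0.29 log units; within the scatter), both fall within the usual scatter, so the three compounds cannot be ranked against one another. The third step, a 1.3-fold lower number from compound 1 to compound 2 (0.10 log units; within the scatter), is likewise within the scatter.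

Compound 4, `COc1cc(OC)cc(C(=O)Nc2ccc(C(=O)/C=C/c3nc(C)c(C)nc3C)cc2)c1`, keeps every atom of compound 3 but arranges the aryl group differently: 3,5-dimethoxyphenyl in place of 2,6-dimethoxyphenyl on a carbonyl carbon. Among the compounds with values here, no measured step moves a methoxy group from one ring position to another; the steps that touch this aryl group exchange it wholesale, and none of them reaches beyond the scatter. On that basis the change from compound 3 to compound 4 is expected to produce no step beyond the scatter in this assay, in either direction, giving an expected step of a 1.1-fold lower number from compound 3 to compound 4 (0.03 log units; within the scatter). Compound 4 is therefore estimated at 2300 nM, with a likely range from 900 nM to 6000 nM.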

Compound 4, half-maximal inhibitory concentration: 6270 nM
Compound 4: the middle estimate sits 2.7-fold (0.44 log units) below what was measured; measured number above the stated range.
By their numbers in this assay, from the lowest: compounds 2, 1 and 3 (each within the scatter of the next); then compound 4.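

Rearranging the two methoxy groups on the ring, with no atom gained or lost, gives the first change in this series to reach beyond the scatter in this assay (a 2.5-fold higher number from compound 3 to compound 4 (0.40 log units; beyond the scatter)). On this carbonyl carbon, 2,4-difluorophenyl, 2-fluorophenyl and 2,6-dimethoxyphenyl could not be told apart, whereas 3,5-dimethoxyphenyl stands clear of the two fluorinated groups as well (a 4.9-fold higher number from compound 2 to compound 4 (0.69 log units; beyond the scatter); a 3.9-fold higher number from compound 1 to compound 4 (0.59 log units; beyond the scatter)), so for these four compounds the arrangement of the groups on the ring matters as well as their identity. No available measurement bears on why this arrangement gives the higher number, so the result records a difference without explaining it.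

Going by these compounds, it remains open whether a plain phenyl or a ring carrying a single methoxy group would fall with compound 3 or with compound 4, and whether a 3,5-difluorophenyl would share the higher number of compound 4. On these data alone, whether the step between compound 3 and compound 4 also appears in other cell lines remains open too.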